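Spiro-hydantoin piperidine amides: cholesterol transporter binding notes

A few compounds are considered here, and "the series" means these few. Any claim that something is new, unique, unknown or untested is made for them only; others in the source may bear on it.

Measured compounds:
compound 1, `CC(C)(C)OC(=O)NCCCNC(=O)CN1CN(c2ccccc2)C2(CCN(C(=O)c3ccc(C(C)(C)C)cc3)CC2)C1=O`: 4500 nM
compound 2, `CC(C)(C)OC(=O)N1CCN(C(=O)CN2CN(c3ccccc3)C3(CCN(C(=O)c4ccc(C5CCCCC5)cc4)CC3)C2=O)CC1`: 3500 nM
compound 3, `O=C(CN1CN(c2ccccc2)C2(CCN(C(=O)c3ccc(C4CCCCC4)cc3)CC2)C1=O)NCCCCO`: 10300 nM

Three compounds of this series have been run in an assay on HEK293 cells for displacement of a labelled ligand from NPC1-like intracellular cholesterol transporter 1 (Homo sapiens); on this read-out lower numbers stand for stronger inhibition and higher numbers for weaker inhibition. Compound 1 gives 4500 nM, the second highest of the three numbers. Compound 2 sits nearest to it, its number lower but within the scatter, so no order can be read between compound 1 and compound 2. Compound 3 lies furthest away, with a higher number that is beyond the scatter, so of the three compounds compound 3 is the one with the weakest displacement of the labelled ligand. All three carry the same spiro-hydantoin piperidine core with an aryl amide on the piperidine nitrogen and a carbonyl-linked substituent on the hydantoin.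

Compound 4, `CCC1CCCN(C(=O)CN2CN(c3ccccc3)C3(CCN(C(=O)c4ccc(C(C)(C)C)cc4)CC3)C2=O)C1`, has not yet been measured in this assay. It differs from compound 1 at one place: 3-ethylpiperidin-1-yl in place of (3-((tert-butoxycarbonyl)amino)propyl)amino on a carbonyl carbon.

Going by the values given here, no step between measured compounds that differ in one place is available, so nothing in the data measures the effect of such a change. The three measured numbers span a narrow range, and compound 4 is expected to remain within that range; the expected step of a 1.1-fold lower number from compound 1 to compound 4 (0.05 log units; within the scatter) is small and may lie within the scatter in either direction. The estimate for compound 4 in this assay is 4000 nM, with a range from 1300 nM to 12000 nM.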

Compound 4, half-maximal inhibitory concentration: 3900 nM
Beside the measured number, compound 4's estimate is 1.0-fold (0.01 log units) above it, and the stated range covers the measured number.
By their numbers in this assay, from the lowest: compounds 2, 4 and 1 (each within the scatter of the next); then compound 3.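

In this assay, the exchange at the carbonyl carbon whose other neighbour is a saturated chain carbon gives the series its first single-place step: 3-ethylpiperidin-1-yl in place of (3-((tert-butoxycarbonyl)amino)propyl)amino gives a 1.2-fold lower number from compound 1 to compound 4 (0.06 log units; within the scatter), so no order can be read between the two compounds. At this position the read-out therefore does not separate a group of 12 heavy atoms with no ring, 2 hydrogen-bond donors and 2 hydrogen-bond acceptors from one of 8 heavy atoms with a six-membered non-aromatic ring and 0 hydrogen-bond donors or acceptors. No available data bear on why the two groups read alike.

Still open, going by these compounds, is whether a carboxylic acid or a primary amine at the end of a longer chain on this carbonyl carbon would give a step beyond the scatter. Also open, on these data alone, is whether the same exchange would read alike in a compound carrying the cyclohexyl group of compound 2 in place of the tert-butyl group on the aryl amide.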